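The source may report more compounds than this note shows. Statements on the series, on what has been measured and on what is new or still open speak of the compounds shown alone.

Of the compounds shown here, three built on a shared core have been tested in a functional assay on KYSE-70 cells for antiproliferative activity against KYSE-70 cell line (Homo sapiens), read by MTT assay, with a stated time of 72 h; on this read-out higher numbers stand for weaker inhibition and lower numbers for stronger inhibition. There, compound 1 (`C#CCSc1nc(Sc2nnnn2CCN(C)C)c(C#N)c(-c2ccc(Cl)cc2)n1`) gives 6560 nM, compound 2 (`C#CCSc1nc(Sc2nccs2)c(C#N)c(-c2ccc(Br)cc2)n1`) gives 10900 nM and compound 3 (`C#CCSc1nc(Sc2nccs2)c(C#N)c(-c2ccc(Cl)cc2)n1`) gives 5350 nM. Compound 3 cannot be told apart from compound 1, with a 1.2-fold lower number from compound 1 to compound 3 (0.09 log units; within the scatter), but it does stand clear of compound 2.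

The next compound, compound 4 (`C#CCSc1nc(Sc2nccs2)c(C#N)c(-c2ccc(C)cc2)n1`), differs from compound 3 in one group: methyl in place of chloro on an aromatic carbon. This is methyl in place of chloro on an aromatic carbon, so 4-chlorophenyl becomes 4-methylphenyl. Among the measured compounds shown here, the most relevant evidence is the one measured swap at this place, chloro in place of bromo, with a 2.0-fold lower number from compound 2 to compound 3 (0.31 log units; beyond the scatter). The swap on the sulfur, between compound 1 and compound 3, lies elsewhere and says little here. For the measured compounds named here, no compound with methyl at this place has been measured, so the direction remains uncertain. Only a small change is expected, a 1.2-fold higher number from compound 3 to compound 4 (0.08 log units; within the scatter), and this estimate may well stay within the scatter. For compound 4 the estimated value is 6500 nM, with an expected range of 3000 nM to 14000 nM.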

Compound 4, half-maximal inhibitory concentration: 4300 nM
The estimate for compound 4 lay 1.5-fold (0.18 log units) above the measured number; measured number inside the range.
By their numbers in this assay, from the lowest: compounds 4, 3, 1 and 2 (each within the scatter of the next, the first and the last beyond it).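

In this assay, methyl in place of chloro on the aromatic carbon gives a 1.2-fold lower number from compound 3 to compound 4 (0.09 log units; within the scatter), so at this position a carbon group can replace a halogen with no change that stands out from the scatter. Methyl in place of bromo does stand out, with a 2.5-fold lower number from compound 2 to compound 4 (0.40 log units; beyond the scatter), which means that compound 2 now sits apart from two compounds that each differ from it only at this position, not just from compound 3. No measurement shown here explains why bromo stands apart from chloro and methyl.

An amine, a methoxy group or a carboxylic acid at this position could move the number in either direction, and these compounds give no guide. On these data alone, the 1-(2-(dimethylamino)ethyl)-1H-tetrazol-5-yl group on the sulfur appears only alongside chloro, so how it behaves with methyl or bromo remains open.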